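Swapping a Hydroxy Group for Pentyl on a Shared Core

The source may report more compounds than this note shows. Statements on the series, on what has been measured and on what is new or still open speak of the compounds shown alone.

Compound 2 `O=c1cc(Cn2cc(CCCO)nn2)c2ccc(O)cc2o1` is one of two close relatives tested in a functional assay on HeLa cells (Homo sapiens) for inhibition, read by MTT assay, with a stated time of 72 h; on this read-out lower numbers stand for stronger inhibition and higher numbers for weaker inhibition. In this assay compound 2 gives 90200 nM. Compound 1 `CC(O)c1cn(Cc2cc(=O)oc3cc(O)ccc23)nn1` gives > 100000 nM, which is a limit of the assay rather than a number. For the measured compounds named here, the only measured step, an at least 1.1-fold lower number from compound 1 to compound 2 (0.04 log units; that floor lies within the scatter), therefore sets no clear direction. Compound 3 `CCCCCCCCc1cn(Cc2cc(=O)oc3cc(O)ccc23)nn1` differs from compound 2 by pentyl in place of hydroxy on a saturated chain carbon, three bonds along the chain from an aromatic carbon. Going by the values given here, no measured step covers a change of this kind, so a step of a 1.5-fold lower number from compound 2 to compound 3 (0.18 log units; within the scatter) is expected, within the scatter. Compound 3 is thus estimated at 60000 nM, between 15000 nM and 200000 nM.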

Compound 3, half-maximal inhibitory concentration: 35100 nM
Beside the measured number, compound 3's estimate is 1.7-fold (0.23 log units) above it; the range from low to high includes it.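

Turning 3-hydroxypropyl into octyl gives a 2.6-fold lower number from compound 2 to compound 3 (0.41 log units; beyond the scatter), the first step in this assay that clears the scatter, so this position does respond to a change of group. Octyl in place of 1-hydroxyethyl gives an at least 2.8-fold lower number from compound 1 to compound 3 (0.45 log units; beyond the scatter). That step is only a floor, as it starts from a limit of the assay and not a number: the limit of > 100000 nM in this assay, at which 1 of the 3 values shown sits.

The compounds shown do not separate the loss of the hydroxy from the gain in chain length. As far as these compounds go, how a longer chain such as decyl, or an amine or a carboxylic acid on this chain, would read remains open.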